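The source may report more compounds than this note shows. Statements on the series, on what has been measured and on what is new or still open speak of the compounds shown alone.

Compound 1 `CC(O)(C[S+]([O-])c1ccc(F)cc1F)C(=O)Nc1ccc([N+](=O)[O-])cc1C(F)(F)F` shows no measurable inhibition in a functional assay on VCaP cells (Homo sapiens) for antiproliferative activity; on this read-out lower numbers stand for stronger inhibition and higher numbers for weaker inhibition: compound 1 gives > 100000 nM, a limit of the assay rather than a number. Compound 2 `CC(O)(C[S+]([O-])c1ccc(C(F)(F)F)cn1)C(=O)Nc1ccc(C#N)c(C(F)(F)F)c1` gives > 100000 nM; > 100000 nM (2 entries), again a limit. Compound 1 therefore stands at the limit of > 100000 nM in this assay, at which 1 of the 2 values shown sits. Compound 3 `CC(O)(C[S+]([O-])c1ccccc1OC(F)(F)F)C(=O)Nc1ccc([N+](=O)[O-])cc1C(F)(F)F` carries 2-(trifluoromethoxy)phenyl in place of 2,4-difluorophenyl on a sulfur, that is, 2-(trifluoromethoxy)phenyl in place of 2,4-difluorophenyl on a sulfur. Among the compounds with values here, no measured step covers this change, and no movement beyond the scatter is expected in this assay. Compound 3 is estimated at 100000 nM, within 30000 nM to 300000 nM. The expected step from compound 1 to compound 3 is a number no higher from compound 1 to compound 3 (the limit leaves the size open), most probably reported as a limit again.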

Compound 3, half-maximal inhibitory concentration: 20700 nM
Estimate against measurement, compound 3: 4.8-fold (0.68 log units) above, and the stated range ends above it.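

In this assay, the aryl group on the sulfur proves able to move the read-out: 2-(trifluoromethoxy)phenyl in place of 2,4-difluorophenyl gives an at least 4.8-fold lower number from compound 1 to compound 3 (0.68 log units; beyond the scatter). Compound 3 is the only compound shown whose value is a number rather than a limit. The full size of the step stays open, since compound 1 is held at a limit: the limit of > 100000 nM in this assay, at which 1 of the 3 values shown sits.

Still open, as far as these compounds go, is whether the oxygen or the trifluoromethyl part of the entering group carries the step. A methoxy or a plain trifluoromethyl group on that phenyl would separate the two.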